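Swapping Chloro for Amino Across Two Related Cores

The compounds below may be only part of what the source reports. "The series", "measured", "known", "first", "only" and "open" are said of these compounds alone.

Of the compounds shown here, three have been measured in a functional assay on SW-620 cells (Homo sapiens) for cytotoxicity, read by sulforhodamine B assay, with a stated time of 48 h; on this read-out lower numbers stand for stronger inhibition of growth and higher numbers for weaker inhibition of growth. Compound 1 `Nc1nc(Cl)c2ncn(Cc3ccc(CCl)cc3)c2n1` gives 13800 nM. Compound 2 `ClCc1cccc(Cn2cnc3c(Cl)nc(Cl)nc32)c1` gives 3460 nM, the lowest of the three numbers, and its step to each of the others is beyond the usual scatter. Compound 3 `ClCc1ccc(Cn2cnc3c(Cl)nc(Cl)nc32)cc1` gives 17400 nM. Compound 3 and compound 2 are built from the same atoms joined differently; the difference between the two cores is not broken down here.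

One change has already been measured once: amino in place of chloro on an aromatic carbon. That change produced a 1.3-fold lower number from compound 3 to compound 1 (0.10 log units; within the scatter), so it barely moved the read-out. Compound 4 `Nc1nc(Cl)c2ncn(Cc3cccc(CCl)c3)c2n1`, still to be measured, arises from compound 2 by the same change, (amino in place of chloro on an aromatic carbon). The surroundings of the changed carbon are described in the same words for both pairs, so this is the same change, now applied to the core that itself sits lower on the read-out.

The expectation for compound 4 rests on that measured pair: because a 1.3-fold lower number from compound 3 to compound 1 (0.10 log units; within the scatter) was small, a similarly small step is expected here. The expected step is a 1.2-fold lower number from compound 2 to compound 4 (0.06 log units; within the scatter). Compound 4 is therefore estimated at 3000 nM, with a plausible range from 1500 nM to 7000 nM. Among the measured compounds shown here, only one earlier example of this change exists, so the expectation is held loosely.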

Compound 4, concentration for total growth inhibition: 11200 nM
Compound 4: middle estimate off by 3.7-fold (0.57 log units), on the low side; measured number outside the range, above it.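

The same swap of chloro for amino behaves differently on the two cores in this assay, and the size of the step measured on one core did not carry over to the other: the same change on two cores in this assay, a 1.3-fold lower number (0.10 log units; within the scatter) from compound 3 to compound 1 and a 3.2-fold higher number (0.51 log units; beyond the scatter) from compound 2 to compound 4, 4.1-fold (0.61 log units) apart, beyond the scatter of two such steps

On this core the change gives a 3.2-fold higher number from compound 2 to compound 4 (0.51 log units; beyond the scatter), so the low number of compound 2 is not kept once amino enters, and compound 4 gives 11200 nM, while compound 1, the amino compound on the other core, gives 13800 nM. What this does not show is why the two steps differ, since two pairs give a contrast between these cores but no rule for any further core, and they offer no measured property that would explain it.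

The compounds shown leave open how other groups on that same aromatic carbon would behave, such as a methoxy group, a methylamino group or a hydroxyl group, and whether any of them would keep the low number of compound 2. They also leave open whether the core dependence seen with amino is particular to that group or would appear with these replacements too.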